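Extending the amide side chain of compound 2

The source may report more compounds than this note shows. Statements on the series, on what has been measured and on what is new or still open speak of the compounds shown alone.

Measured compounds:
compound 1 `C[C@H](NC(=O)CN(c1nc(Cl)nc2[nH]cnc12)C1CC1)C(=O)OCc1ccccc1`: 23%
compound 2 `O=C(CN(c1ncnc2c1ncn2C1CCCCO1)C1CC1)NCC(=O)OCc1ccccc1`: 7.26%
compound 3 `CC[C@H](C)[C@H](NC(=O)CN(c1nc(Cl)nc2[nH]cnc12)C1CC1)C(=O)O`: 6.71%

In a functional assay on the whole organism (Tail, strain ICR) with Mus musculus as the target, in the tail flick test, with a stated time of 150 min, at a dose of 25 umol/kg by the oral route (a lower number here means a weaker effect, a higher number a stronger effect of the compound at the dose given), compound 2 gives 7.26%, the second highest of the three numbers. Compound 3 lies nearest to it, within the scatter of this assay, so no order between compound 2 and compound 3 can be read. Compound 1 lies furthest away, beyond the scatter, and gives 23%.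

The unmeasured compound 4 `O=C(CN(c1ncnc2c1ncn2C1CCCCO1)C1CC1)N[C@@H](CC(=O)OCc1ccccc1)C(=O)OCc1ccccc1` keeps the core of compound 2 and differs from it in one place: (benzyloxycarbonyl)methyl in place of hydrogen on a saturated chain carbon bound to an amide-type nitrogen and a carbonyl carbon. Among the measured compounds shown here, no pair of measured compounds differing in one place is available, so the size of this step has no precedent among the three measured compounds. The expected step from compound 2 to compound 4 in this assay is a number 4.7 percentage points higher from compound 2 to compound 4 (within the scatter), a small rise that could well stay within the scatter. Compound 4 is therefore expected to give 12%, with a range from 2% to 28%.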

Compound 4, a percentage reported as activity, at one dose (the size of the read-out at that dose, not a potency): 0.06%
For compound 4 the middle estimate is 11.9 percentage points above the measured one, outside the stated range (below it).
By their numbers in this assay, from the lowest: compounds 4, 3 and 2 (each within the scatter of the next); then compound 1.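

In this assay, putting (benzyloxycarbonyl)methyl in place of hydrogen on a saturated chain carbon bound to an amide-type nitrogen and a carbonyl carbon gives a number 7.2 percentage points lower from compound 2 to compound 4 (within the scatter). Among the compounds shown here, this is the first single-place step at this position, and it shows that a group of 11 heavy atoms with its own six-membered aromatic ring brings no gain there that stands clear of the scatter, while no order can be read between the two compounds. Nothing available bears on why this step has the size it has.

The compounds shown leave open whether a smaller group on this carbon, such as methyl, or a free carboxylic acid on the new side chain in place of the benzyl ester, would move the number beyond the scatter. They also leave open whether the same step would have a similar size on the core of compound 1.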